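The source may report more compounds than this note shows. Statements on the series, on what has been measured and on what is new or still open speak of the compounds shown alone.

Working notes on the series, read in a functional assay on HeLa cells (Homo sapiens) for antiproliferative activity, read by MTT assay, with a stated time of 48 h; a higher number here means a weaker inhibitor, a lower number a stronger inhibitor. Of the compounds shown here, two have numbers so far. Compound 1 (`COc1cc(-c2nnc3c(OC4CCC4)cc(-c4ccc5[nH]ccc5c4)cn23)cc(OC)c1OC`) gives 142 nM, and compound 2 (`COc1cc(-c2nnc3c(OC4COC4)cc(-c4ccc5c(ccn5C)c4)cn23)cc(OC)c1OC`) gives 214 nM. These two values lie within the scatter of each other, so compound 2 stands level with compound 1 on the numbers shown.

Compound 3 (`COc1cc(-c2nnc3c(OC4CCC4)cc(-c4ccc5c(ccn5C)c4)cn23)cc(OC)c1OC`) has not yet been measured in this assay. It follows from compound 2 by a single change, cyclobutyl in place of oxetan-3-yl on an oxygen on an aromatic ring. Within the data shown here, no two measured compounds differ in one place only, so the series offers no direct measure of this change.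

The expectation is a small step at most, not clearly beyond the scatter, with a slight lean towards a lower number in this assay. The estimate amounts to an expected step of a 1.4-fold lower number from compound 2 to compound 3 (0.15 log units; within the scatter). For compound 3 the estimated value is 150 nM, with an expected range of 55 nM to 400 nM.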

Compound 3, half-maximal inhibitory concentration: 177 nM
Beside the measured number, compound 3's estimate is 1.2-fold (0.07 log units) below it; the range from low to high includes it.
By their numbers in this assay, from the lowest: compounds 1, 3 and 2 (each within the scatter of the next).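

In this assay, the exchange on the oxygen on an aromatic ring now has a direct reading: cyclobutyl in place of oxetan-3-yl gives a 1.2-fold lower number from compound 2 to compound 3 (0.08 log units; within the scatter), so with the methyl on the aromatic nitrogen held constant, removing the ring oxygen produces no difference that can be told from the scatter. Among these compounds, compound 3 also gives the first reading at the aromatic nitrogen, where methyl in place of hydrogen, with cyclobutyl held constant on the oxygen, gives a 1.2-fold higher number from compound 1 to compound 3 (0.10 log units; within the scatter), so this second change cannot be told from the scatter either. No accompanying measurement offers an explanation for either reading.

Among the compounds shown here, these readings cover only two four-membered rings on the oxygen and only hydrogen or methyl on the aromatic nitrogen, so it remains open whether an open-chain ether such as methoxyethyl, or an amine such as a dimethylaminoethyl chain, would stay within the scatter at the same place. Also open, going by these compounds, is whether either step would remain this small with a different group elsewhere on the shared core.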